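The source may report more compounds than this note shows. Statements on the series, on what has been measured and on what is new or still open speak of the compounds shown alone.

For the measured compounds named here, compound 3 `COc1ccc(N(C)c2nc(C)nc3ccccc23)cc1C(=O)OCC[Se]C#N` stands at the top of the three numbers measured so far in a functional assay on LoVo cells (Homo sapiens) for inhibition, read by MTT assay, with a stated time of 48 h; on this read-out higher numbers stand for weaker inhibition and lower numbers for stronger inhibition: compound 3 gives 2960 nM, while compound 1 `COc1ccc(N(C)c2nc(C)nc3ccccc23)cc1C(=O)OCCCCC[Se]C#N` gives 714 nM and compound 2 `C[Se]c1ccc(N(C)c2nc(C3CC3)nc3ccccc23)cc1` gives 11 nM. Compound 3 is thus the weakest inhibitor of the three, its distance from each of the other two lying beyond the scatter. The new compound 4 `COc1ccc(N(C)c2nc(C)nc3ccccc23)cc1OCCCC[Se]C#N` differs from compound 3 by a group of 8 heavy atoms (5 carbon, 1 nitrogen, 1 oxygen, 1 selenium; no ring) in place of a group of 8 heavy atoms (4 carbon, 1 nitrogen, 2 oxygen, 1 selenium; no ring), on an aromatic carbon. Going by the values given here, the one measured step that bears on this change is the one within the same selenocyanate-bearing chain: a 4.1-fold higher number from compound 1 to compound 3 (0.62 log units; beyond the scatter), where the longer chain went with the lower number. Compound 4 returns to a long chain of that kind, though now joined to the ring through an oxygen rather than through an ester. Compound 2 carries its selenium directly on the ring and a different group on the core, so its value shows only that a far lower number is reachable among these compounds, not how this particular change will act. The writer therefore expects compound 4 to move back toward compound 1, with an expected step of a 4.2-fold lower number from compound 3 to compound 4 (0.63 log units; beyond the scatter) because of a 4.1-fold higher number from compound 1 to compound 3 (0.62 log units; beyond the scatter) read in reverse. Compound 4 is expected to give about 700 nM, within a range of 250 nM to 2500 nM.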

Compound 4, half-maximal inhibitory concentration: 882 nM
Compound 4: middle estimate off by 1.3-fold (0.10 log units), on the low side; low and high end bracket the measured number.
By their numbers in this assay, from the lowest: compound 2; then compounds 1 and 4 (each within the scatter of the next); then compound 3.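

In this assay, the step at this aromatic carbon, ortho to a methoxy group, is a 3.4-fold lower number from compound 3 to compound 4 (0.53 log units; beyond the scatter). It shows that the ester carbonyl is not required for a number well under that of compound 3: the entering group has no double bond outside aromatic rings and one hydrogen-bond acceptor fewer than the group it replaces, at the same count of heavy atoms. Compound 1 (714 nM) and compound 4 (882 nM) lie within the scatter of each other, so the ester-linked long chain and the oxygen-linked chain give values that cannot be told apart here, although the step from compound 3 changes both the link and the chain length at once, so neither can be credited alone. No measurement at hand explains the shift.

The compounds shown leave open how much of the step belongs to the link and how much to the chain, which an oxygen-linked chain of the same length as in compound 3 would help to separate. They also leave open whether an amide link or a longer chain at this position would move the number toward that of compound 2 (11 nM), which differs from the others in more than one place.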